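Swapping a methylsulfonyl for a trifluoromethyl on the aryl tail

This account rests on a few compounds, and the source may have more. Where it says the series, first, only, none or still open, it means among the compounds named here.

Measured compounds:
Compound 1, `O=C(CCCCC#Cc1ccc([N+](=O)[O-])cc1)c1ncc(-c2ccccn2)o1`, 31 nM
Compound 2, `CS(=O)(=O)c1cccc(CCCCCCC(=O)c2ncc(-c3ccccn3)o2)c1`, 1.3 nM
Compound 3, `Nc1ccc(CCCCCCC(=O)c2ncc(-c3ccccn3)o2)cc1`, 3 nM

All three compounds share a core and differ in the aromatic tail at the end of the chain. In an assay for inhibition of Fatty-acid amide hydrolase 1 (Rattus norvegicus) (a higher number here means a weaker inhibitor, a lower number a stronger inhibitor), compound 2 gives the lowest number of the three and so is the strongest inhibitor here; compound 3 is the nearest to it and compound 1 the furthest, and both gaps lie beyond the usual scatter of this assay.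

Compound 4, `O=C(CCCCCCc1cccc(C(F)(F)F)c1)c1ncc(-c2ccccn2)o1`, has not yet been measured. It differs from compound 2 in one place: trifluoromethyl in place of methylsulfonyl on an aromatic carbon. Going by the values given here, no measured pair shows this exact exchange, so its effect has to be judged from the spread of the tail groups already seen, which all keep the inhibition constant low. A small to moderate rise in the number, in the direction of weaker inhibition, seems plausible, though a result within the scatter would not be surprising.

Compound 4 is therefore expected to give 4 nM in this assay, within a range of 1.3 nM to 12 nM, which means an estimated step of a 3.1-fold higher number from compound 2 to compound 4 (0.49 log units; beyond the scatter).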

Compound 4, inhibition constant: 1 nM
The estimate for compound 4 lay 4.0-fold (0.60 log units) above the measured number, and the stated range ends above it.
By their numbers in this assay, from the lowest: compounds 4 and 2 (each within the scatter of the next); then compound 3; then compound 1.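

In this assay, trifluoromethyl in place of methylsulfonyl on this aromatic carbon gives a 1.3-fold lower number from compound 2 to compound 4 (0.11 log units; within the scatter), so compound 2 and compound 4 cannot be told apart. Going by these compounds alone, this is the first direct exchange at this place on the tail: the group that leaves carries hydrogen-bond acceptors and the group that enters carries none, yet the number stays in the same low range, so acceptors in this group are not required for strong inhibition in this pair. No measurement here explains why the two groups match.

As far as these compounds go, it remains open whether a much smaller or differently charged group on the same carbon, such as a bare hydrogen or a carboxylic acid, would match as well. From the compounds shown here alone, it is equally open whether trifluoromethyl would do so on another aromatic carbon of the ring.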